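The compounds below may be only part of what the source reports. "The series", "measured", "known", "first", "only" and "open" are said of these compounds alone.

Within the data shown here, in a functional assay on SW480 cells (Homo sapiens) for antiproliferative activity, read by MTT assay, with a stated time of 48 h (a higher number here means a weaker inhibitor, a lower number a stronger inhibitor), compound 1 `CC(=O)OC/C1=C/C[C@](C)(CCC=C(C)C)/C=C/[C@@H](OC(=O)C=C(C)C)[C@](C)(O)/C=C/C1=O` gives 2950 nM and compound 2 `CO/N=C/C1=C/C[C@](C)(CCC=C(C)C)/C=C/[C@@H](OC(=O)C=C(C)C)[C@](C)(O)/C=C/C1=O` gives 2630 nM, so compound 2 stands level with its only measured neighbour. Among the measured compounds shown here, the one measured step, a 1.1-fold lower number from compound 1 to compound 2 (0.05 log units; within the scatter), exchanged one group for another on a double-bonded ring carbon and left the read-out within the scatter. Compound 3 `CC(C)=CCC[C@]1(C)/C=C/[C@@H](OC(=O)C=C(C)C)[C@](C)(O)/C=C/C(=O)/C(C(=O)N(C(C)C)C(C)C)=C\C1` alters that same ring carbon again: a group of 9 heavy atoms (7 carbon, 1 nitrogen, 1 oxygen; no ring) in place of a group of 4 heavy atoms (2 carbon, 1 nitrogen, 1 oxygen; no ring), on a double-bonded ring carbon. For the measured compounds named here, the entering diisopropylcarbamoyl group is bigger than either group measured so far, and no other compound here carries it, so the single flat step is weak guidance. Starting from compound 2 at 2630 nM, no change beyond the scatter is expected in this assay, though with wide uncertainty. The expected change is a 1.3-fold higher number from compound 2 to compound 3 (0.11 log units; within the scatter). For compound 3 the estimated value is 3400 nM, with an expected range of 1300 nM to 9000 nM.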

Compound 3, half-maximal inhibitory concentration: 16000 nM
For compound 3 the middle estimate is 4.7-fold (0.67 log units) below the measured one, outside the stated range (above it).
By their numbers in this assay, from the lowest: compounds 2 and 1 (each within the scatter of the next); then compound 3.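

In this assay, this double-bonded ring carbon turns out not to be indifferent to what it carries, which the flat step between the two earlier groups could not show. Diisopropylcarbamoyl gives a 6.1-fold higher number from compound 2 to compound 3 (0.78 log units; beyond the scatter), and set against acetoxymethyl it gives a 5.4-fold higher number from compound 1 to compound 3 (0.73 log units; beyond the scatter), so both steps run the same way and lie beyond the scatter. Nothing available explains this rise.

Compound 3 is the only amide shown, so it remains open whether the rise goes with the larger group count or with the amide itself. A dimethylcarbamoyl group, an unsubstituted carboxamide or a carboxylic acid on this same ring carbon would help to separate the two, and whether any group here could lower the number also stays unanswered.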